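Carbamate step in a series held at assay limits

The source may report more compounds than this note shows. Statements on the series, on what has been measured and on what is new or still open speak of the compounds shown alone.

Measured so far in a functional assay on the whole organism with Mus musculus as the target (a lower number here means that less compound is needed, a higher number that more compound is needed for the effect), all as limits:
- compound 1 `Cc1c(C)c2c(c(N)c1N)CC(C)(C)O2` gives > 50 mg/kg as a limit
- compound 2 `Cc1c(C)c2c(c(C)c1NC=O)CC(C)(C)O2` gives > 100 mg/kg as a limit
- compound 3 `CC(=O)Nc1c(C)c(C)c2c(c1C)CC(C)(C)O2` gives > 100 mg/kg as a limit

Compound 3 stands at the limit of > 100 mg/kg in this assay, at which 2 of the 3 values shown sit ( a limit, not a number ) and so has no numerical place in the series. Compound 4 `CCOC(=O)Nc1c(C)c(C)c2c(c1C)CC(C)(C)O2` keeps the shared core and carries ethoxy in place of methyl on a carbonyl carbon. Among the measured compounds shown here, the only measured step on this carbonyl carbon is a step that the two limits leave unreadable from compound 2 to compound 3 and it offers no size to carry over. For the measured compounds named here, no step of definite size or direction is therefore expected in this assay for this change. With compound 3 at > 100 mg/kg as a limit, compound 4 is expected to end at a limit as well. The expected step is a number no higher from compound 3 to compound 4 (the limit leaves the size open) and it is poorly constrained. For compound 4 the estimate is 100 mg/kg (expected range 40 mg/kg to 300 mg/kg) and it rests on limits alone.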

Compound 4, dose for 50% inhibition: > 100 mg/kg
Compound 4: a limit, no number; the forecaster's own chance of this, stated with the estimate: 75%; the middle value sits exactly at the limit.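

In this assay compound 4 gives > 100 mg/kg, a limit and not a number. No step from compound 2 or compound 3 to compound 4 can be read, and all three stand at the same limit: the limit of > 100 mg/kg in this assay, at which 3 of the 4 values shown sit.

Whether any change on this carbonyl carbon shifts the dose in this assay stays open, with no numerical value among the compounds shown.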